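The source may report more compounds than this note shows. Statements on the series, on what has been measured and on what is new or still open speak of the compounds shown alone.

In a physicochemical assay for solubility (a lower number here means a less soluble compound, a higher number a more soluble compound), compound 2 (`CNC(=O)c1cc(C(=O)NC2CC2)cn(Cc2cccc(F)c2)c1=O`) reads >= 133 ug/mL as a limit and not as a number. The other two measured compounds are also known only by limits. Compound 1 (`CNC(=O)c1cc(C(=O)NCCCC2CNCCO2)cn(Cc2ccccc2)c1=O`) reads >= 194 ug/mL as a limit. Compound 3 (`CNC(=O)c1cc(C(=O)NCCC2CCOCC2)cn(Cc2ccccc2)c1=O`) reads >= 127 ug/mL as a limit. Compound 2 therefore stands on no exact number, and it cannot be ranked against either of the others.

In compound 4 (`CNC(=O)c1cc(C(=O)NC2CC2)cn(Cc2cccc3cn[nH]c23)c1=O`) 1H-indazol-7-yl stands in place of 3-fluorophenyl on a saturated chain carbon bound to an aromatic nitrogen, and the full count reads 1H-indazol-7-yl in place of 3-fluorophenyl on a saturated chain carbon bound to an aromatic nitrogen for this change. Among the compounds with values here, the only measured step, a step that the two limits leave unreadable from compound 1 to compound 3 as it stands, has no readable size. It also concerns oxan-4-yl in place of (morpholin-2-yl)methyl on a saturated chain carbon, which is not the place changed here. Within the data shown here, no measured step therefore gives a size or a direction for this change, and no step beyond the usual scatter is expected in this assay on present data. The expected change by this estimate is an at least 1.0-fold lower number from compound 2 to compound 4 (0.00 log units; that floor lies within the scatter) for this pair. For compound 4 the expected solubility is 130 ug/mL with an estimated range of 60 ug/mL to 200 ug/mL for the measurement.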

Compound 4, solubility: >= 181 ug/mL
Compound 4 was reported as a limit; the forecaster's own chance of this, stated with the estimate: 45%; middle value at least 1.3-fold (0.14 log units) away from the limit.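

Compound 2 and compound 4 are both known only as limits in this assay, so no step can be read between them. The compounds shown leave open where the true read-outs of all four compounds lie in this assay, and whether 1H-indazol-7-yl in place of 3-fluorophenyl changes the read-out at all.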